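Side chain trimmed to propyl: expected loss of potency

A few compounds are considered here, and "the series" means these few. Any claim that something is new, unique, unknown or untested is made for them only; others in the source may bear on it.

Within the data shown here, compound 1 `O=C1O[C@H]([C@@H](O)Cn2cc(CNS(=O)(=O)c3ccc(Cl)cc3F)nn2)C(OCc2ccccc2)=C1OCc1ccccc1` is the one member of the series with a numeric read-out: in a functional assay on A549 cells (Homo sapiens) for antiproliferative activity, read by MTT assay, with a stated time of 72 h (a higher number here means a weaker inhibitor, a lower number a stronger inhibitor), compound 1 gives 39100 nM, and it therefore stands alone among the numbers in hand. Compound 2 `O=C1O/C(=C\Cn2cc(-c3ccc(Br)cc3)nn2)C(OCc2ccccc2)=C1OCc1ccccc1` returns only a limit in this assay, > 100000 nM. Among the measured compounds shown here, no pair of measured compounds differs in a single place, so no measured step is available to calibrate the series.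

Compound 3 `CCCCc1cn(C[C@H](O)[C@H]2OC(=O)C(OCc3ccccc3)=C2OCc2ccccc2)nn1` differs from compound 1 in one place: propyl in place of ((4-chloro-2-fluorophenyl)sulfonyl)amino on a saturated chain carbon bound to an aromatic carbon. The ((4-chloro-2-fluorophenyl)sulfonyl)amino group leaves and a propyl enters on a saturated chain carbon bound to an aromatic carbon. For the measured compounds named here, the only guide is that one of the two values sits at the limit (the limit of > 100000 nM in this assay, at which 1 of the 2 values shown sits). A weakening beyond the scatter is expected, with a real chance that only a limit is reported. For compound 3 the estimated value in this assay is 75000 nM, within 25000 nM to 200000 nM. The step this estimate means, a 1.9-fold higher number from compound 1 to compound 3 (0.28 log units; within the scatter), is expected to exceed the scatter.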

Compound 3, half-maximal inhibitory concentration: 28600 nM
Compound 3: the middle estimate sits 2.6-fold (0.42 log units) above what was measured; the measured number falls inside the stated range.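

In this assay, this exchange gives a 1.4-fold lower number from compound 1 to compound 3 (0.14 log units; within the scatter). Among these compounds, this is the first measured step, and it shows that on a saturated chain carbon bound to an aromatic carbon, propyl can stand in place of ((4-chloro-2-fluorophenyl)sulfonyl)amino with no difference beyond the scatter. At this place, then, the six-membered aromatic ring and the hydrogen-bond donor and acceptors of the departing group are not needed to keep a numeric read-out in this range.

Going by these compounds, whether a longer chain, an amine or a carboxylic acid at this place would move the number beyond the scatter remains open. Compound 2 stands only as a limit and differs from the other compounds in more than one place, so no step to it can be read: the limit of > 100000 nM in this assay, at which 1 of the 3 values shown sits.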